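This account rests on a few compounds, and the source may have more. Where it says the series, first, only, none or still open, it means among the compounds named here.

Compound 1 `COc1ccc(/C=C/C(=O)c2ccc(NC(=O)CBr)cc2)cc1` in a functional assay on the whole organism (strain albino) for inhibition, with Rattus norvegicus as the target, read by paw edema, with stated times of 30 min and 5 h, at a dose of 100 mg/kg by the oral route (on this read-out higher numbers stand for more inhibition at the one dose given (going by the name of the read-out) and lower numbers for less inhibition), gives 34%. Within the data shown here, its only measured neighbour is compound 2 `COc1ccc(/C=C/C(=O)c2ccc(NC(=O)C(C)Br)cc2)cc1`, which in this assay gives 31%; the step of a number 3 percentage points lower from compound 1 to compound 2 (within the scatter) lies within the scatter, so neither compound can be set apart from the other on these two numbers. Compound 3 `COc1ccc(/C=C/C(=O)c2ccc(NC(=O)COc3ccc(/C(C)=N\O)cc3)cc2)cc1` has not yet been measured. It differs from compound 1 as follows: a group of 11 heavy atoms (8 carbon, 1 nitrogen, 2 oxygen; one six-membered aromatic ring of carbon only) in place of one bromine atom, on a saturated chain carbon bound to a carbonyl carbon. Among the measured compounds shown here, this change sits at the same saturated chain carbon as the step from compound 1 to compound 2, but that step only exchanged a hydrogen for a methyl and kept the bromine, so no measured step shows what happens when the bromine itself is replaced by a group of this size. For compound 3 the estimate in this assay is 35%, with a range from 20% to 50%. The step this estimate implies, a number 1 percentage points higher from compound 1 to compound 3 (within the scatter), is expected to stay within the scatter.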

Compound 3, a percentage reported as inhibition, in the whole organism at one dose (the size of the read-out at that dose, not a potency): 37%
Compound 3: the middle estimate sits 2 percentage points below what was measured; the range from low to high includes it.
By their numbers in this assay, from the lowest: compounds 2, 1 and 3 (each within the scatter of the next).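

In this assay, exchanging the bromo group for the group of 11 heavy atoms with its six-membered aromatic ring gives a number 3 percentage points higher from compound 1 to compound 3 (within the scatter), on a saturated chain carbon bound to a carbonyl carbon. The earlier pair both kept the bromine and differed only by a methyl in place of hydrogen, whereas this result shows that the read-out at this one dose does not depend on the bromine being present and that a much larger group is accepted at this place. The data give no explanation for this outcome.

As far as these compounds go, it remains open how a small replacement for the bromine, such as an amine or a carboxylic acid, would behave at this carbon. From the compounds shown here alone, it is also open whether the six-membered aromatic ring alone, without the rest of the entering group, would give the same read-out.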